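A few compounds are considered here, and "the series" means these few. Any claim that something is new, unique, unknown or untested is made for them only; others in the source may bear on it.

In an assay on isolated protein for inhibition of Amine oxidase [flavin-containing] B (Homo sapiens), read by fluorescence, with a stated time of 15 min (a higher number here means a weaker inhibitor, a lower number a stronger inhibitor), compound 2 `O=C1OCc2cc(OCc3ccc(F)cc3)ccc21` gives 8.35 nM, while compound 1 `O=C1OCc2cc(OCc3ccc(Cl)cc3)ccc21` gives 13.9 nM. Among the measured compounds shown here, the one change between them, (chloro in place of fluoro on an aromatic carbon), made a step of a 1.7-fold higher number from compound 2 to compound 1 (0.22 log units; within the scatter). Compound 3 `CC(=O)c1ccc(OCc2ccc(F)cc2)cc1F` is built on another core, and the difference between the two cores is not broken down here. In this assay compound 3 gives 56.9 nM, a higher number than either compound 1 or compound 2, and the gaps to both lie beyond the scatter. Compound 4 `CC(=O)c1ccc(OCc2ccc(Cl)cc2)cc1F` has not yet been measured. It differs from compound 3 by chloro in place of fluoro on an aromatic carbon, the same change as that seen between compound 2 and compound 1, set on an aromatic carbon para to a large group in both cases. For compound 4 a step of a 1.6-fold higher number from compound 3 to compound 4 (0.20 log units; within the scatter) is expected, because the earlier step was only a 1.7-fold higher number from compound 2 to compound 1 (0.22 log units; within the scatter) and lay within the scatter. Compound 4 is therefore estimated to give 90 nM in this assay, with a likely range from 40 nM to 200 nM.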

Compound 4, half-maximal inhibitory concentration: 52.9 nM
The estimate for compound 4 lay 1.7-fold (0.23 log units) above the measured number; the measured number falls inside the stated range.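

In this assay, on the second core, chloro in place of fluoro on an aromatic carbon gave a step of a 1.1-fold lower number from compound 3 to compound 4 (0.03 log units; within the scatter), so here too the change leaves the number within the scatter. Set beside the step on the first core, this step does not differ from it by more than repeated measurement would allow: the same change on two cores in this assay, a 1.7-fold higher number (0.22 log units; within the scatter) from compound 2 to compound 1 and a 1.1-fold lower number (0.03 log units; within the scatter) from compound 3 to compound 4, 1.8-fold (0.25 log units) apart, within the scatter of two such steps. This shows that the change carried over between these two cores as a step within the scatter, but with one pair on each core it does not show that it would do so on any further core, and the two steps pointing in opposite directions carries no weight.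

The compounds shown leave open what a larger halogen such as bromo, or a group such as methoxy, would give on an aromatic carbon para to a large group. They also leave open whether an amine or a carboxylic acid at that place would behave differently on the two cores.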